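Heptyl replaced by hydroxy in a bisphenol series

This account rests on a few compounds, and the source may have more. Where it says the series, first, only, none or still open, it means among the compounds named here.

Measured compounds:
compound 1, `COc1cc(C(c2ccc(O)c(OC)c2)[C@@H](C)[C@@H](C)CF)ccc1O`: 38000 nM
compound 2, `CCCCCCCC[C@H](C(C)C)C(c1ccc(O)c(OC)c1)c1ccc(O)c(OC)c1`: 3700 nM

Of the compounds shown here, two share the same core and have been tested in a functional assay on HL-60 cells (Homo sapiens) for cytotoxicity, read by WST assay, with a stated time of 48 h; on this read-out lower numbers stand for stronger inhibition and higher numbers for weaker inhibition. Compound 2 stands at the lowest of the two numbers; the nearest, compound 1, sits at a higher number, and that gap is beyond the usual scatter. The pair differ in more than one place, so only their two values can be compared.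

Compound 3, `COc1cc(C(c2ccc(O)c(OC)c2)[C@H](CO)C(C)C)ccc1O`, has not yet been measured in this assay. Its structure differs from compound 2 in one place: hydroxy in place of heptyl on a saturated chain carbon, three bonds along the chain from two aromatic carbons.

Among the measured compounds shown here, no step between measured compounds is available for this change. Compound 1, which also carries only a short substituent on the saturated chain, gives 38000 nM, and that number is taken as the nearer guide. The expected step from compound 2 to compound 3 is an 8.1-fold higher number from compound 2 to compound 3 (0.91 log units; beyond the scatter), an increase beyond the scatter. Compound 3 is accordingly estimated at 30000 nM, in a range from 8000 nM to 100000 nM.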

Compound 3, half-maximal inhibitory concentration: > 100000 nM
Compound 3 gave a limit, no number; the forecaster's own chance of this, stated with the estimate: 20%; middle value at least 3.3-fold (0.52 log units) from the limit.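

In this assay compound 3 gives no number, only a limit of the assay: the limit of > 100000 nM in this assay, at which 1 of the 3 values shown sits. Hydroxy in place of heptyl on a saturated chain carbon, three bonds along the chain from two aromatic carbons, gives an at least 27-fold higher number from compound 2 to compound 3 (1.43 log units; beyond the scatter), the first change in one place that can be read at this position, and it is a large one. The short substituents do not all sit at one level either: 1-(hydroxymethyl)-2-methylpropyl in place of 2-(fluoromethyl)-1-methylpropyl on a saturated chain carbon bound to two aromatic carbons gives an at least 2.6-fold higher number from compound 1 to compound 3 (0.42 log units; beyond the scatter), a step beyond the scatter.

As far as these compounds go, with only a limit for compound 3, the full size of both steps stays unknown. From the compounds shown here alone, whether a butyl chain at this carbon would read nearer to compound 2 or to compound 3, and whether an amine would read differently from hydroxy, also stays open.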